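A Silicon-Bearing Group Replaces 4-methylpiperazin-1-yl

The compounds below may be only part of what the source reports. "The series", "measured", "known", "first", "only" and "open" are said of these compounds alone.

Of the compounds shown here, two sharing one core have been measured in a functional assay on A549 cells (Homo sapiens) for antiproliferative activity, read by MTT assay, with a stated time of 48 h; a lower number here means a stronger inhibitor, a higher number a weaker inhibitor. Compound 1 `CC(C)=CCC[C@]1(C)/C=C/[C@@H](OC(=O)C=C(C)C)[C@](C)(O)/C=C/C(=O)/C(CN(C(C)C)C(C)C)=C\C1`, with diisopropylamino on a saturated chain carbon bound to a double-bonded ring carbon, gives 650 nM. Compound 2 `CC(C)=CCC[C@]1(C)/C=C/[C@@H](OC(=O)C=C(C)C)[C@](C)(O)/C=C/C(=O)/C(CN2CCN(C)CC2)=C\C1`, with 4-methylpiperazin-1-yl in that place, gives 940 nM. The two values lie within the scatter of each other, so compound 2 holds no rank apart from compound 1.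

Compound 3 `CC[Si](CC)(CC)C/C1=C/C[C@](C)(CCC=C(C)C)/C=C/[C@@H](OC(=O)C=C(C)C)[C@](C)(O)/C=C/C1=O` has not yet been measured in this assay. It differs from compound 2 by one change: a group of 7 heavy atoms (6 carbon, 1 silicon; no ring) in place of a group of 7 heavy atoms (5 carbon, 2 nitrogen; one six-membered non-aromatic ring with 2 hetero atoms), on a saturated chain carbon bound to a double-bonded ring carbon. Among the measured compounds shown here, only one measured step bears on this change, a 1.4-fold higher number from compound 1 to compound 2 (0.16 log units; within the scatter), and it lies within the scatter. That step exchanges one nitrogen-bearing group for another, while the group in compound 3 holds only carbon and silicon, so it offers limited guidance. For the measured compounds named here, no measured compound shows the effect of such a group, and no direction can be favoured. No step beyond the scatter is therefore expected, although the range must stay wide. The estimated step is a 1.1-fold higher number from compound 2 to compound 3 (0.03 log units; within the scatter). For compound 3 the expected value is 1000 nM, with an estimated range of 300 nM to 3500 nM.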

Compound 3, half-maximal inhibitory concentration: 3100 nM
The estimate for compound 3 lay 3.1-fold (0.49 log units) below the measured number, and the stated range covers the measured number.
By their numbers in this assay, from the lowest: compounds 1 and 2 (each within the scatter of the next); then compound 3.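

The silicon-bearing group gives a 3.3-fold higher number from compound 2 to compound 3 (0.52 log units; beyond the scatter) and a 4.8-fold higher number from compound 1 to compound 3 (0.68 log units; beyond the scatter) in this assay, both modest steps beyond the scatter. Diisopropylamino and 4-methylpiperazin-1-yl could not be told apart at this saturated chain carbon bound to a double-bonded ring carbon, but the result shows that the activity at this place is not indifferent to the group it carries: among these three compounds, the one group without nitrogen stands apart from both amines, with the highest number. Nothing measured here explains this shift.

Compound 3 both introduces silicon and removes nitrogen, so the compounds shown cannot say which of the two goes with the higher number; a triethyl-substituted carbon in place of the triethylsilyl group would bear on that question. From the compounds shown here alone, it also remains open whether other amines, such as dimethylamino or morpholin-4-yl, would stay within the scatter of compound 1 and compound 2 or move away from them.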